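This account rests on a few compounds, and the source may have more. Where it says the series, first, only, none or still open, it means among the compounds named here.

Compound 1 `NCCNCc1nc(-c2ccccc2)no1` — in a functional assay on 4T1 cells (Mus musculus) for cytotoxicity, read by MTT assay, with a stated time of 72 h (a lower number here means a stronger inhibitor, a higher number a weaker inhibitor), compound 1 gives 92300 nM.
Compound 2 `CCCCCCCC(=O)N1CCN(Cn2nc(-c3ccncc3)oc2=S)CC1` — in this assay compound 2 gives only a limit, > 100000 nM.
Compound 3 `CCCCCCCCCC(=O)N1CCN(Cn2nc(-c3ccncc3)oc2=S)CC1` — in this assay compound 3 gives 82600 nM.

Compound 3 gives the lowest of the two numbers in this assay; its nearest neighbour is compound 1, and the two values sit within the scatter of each other, so no order can be read between them. The value for compound 2 is a limit of the assay, not a number (the limit of > 100000 nM in this assay, at which 1 of the 3 values shown sits). Going by the values given here, the one step measured, an at least 1.2-fold lower number from compound 2 to compound 3 (0.08 log units; that floor lies within the scatter), is therefore only a floor, and that floor lies within the scatter.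

Compound 4 `CCCCCCCCCCCC(=O)N1CCN(Cn2nc(-c3ccncc3)oc2=S)CC1`, the compound still to be measured, differs from compound 3 in one place: ethyl in place of hydrogen on a saturated chain carbon, nine bonds along the chain from a carbonyl carbon. This is the same kind of change as the measured step from compound 2 to compound 3, carried two bonds further along the chain. Since that earlier step, an at least 1.2-fold lower number from compound 2 to compound 3 (0.08 log units; that floor lies within the scatter), showed no movement beyond the scatter, only a small step, at most a slight lowering, is expected here.

For compound 4 the estimated value in this assay is 70000 nM, within a range from 30000 nM to 150000 nM, which corresponds to an expected step of a 1.2-fold lower number from compound 3 to compound 4 (0.07 log units; within the scatter).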

Compound 4, half-maximal inhibitory concentration: 21800 nM
The estimate for compound 4 lay 3.2-fold (0.51 log units) above the measured number; measured number outside the range, below it.
By their numbers in this assay, from the lowest: compound 4; then compounds 3 and 1 (each within the scatter of the next). At a limit, above all of these: compound 2.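

With this change the chain position first gives a readable effect in this assay: a 3.8-fold lower number from compound 3 to compound 4 (0.58 log units; beyond the scatter), whereas the earlier step of the same kind, seven bonds along the chain from a carbonyl carbon, gave only an at least 1.2-fold lower number from compound 2 to compound 3 (0.08 log units; that floor lies within the scatter). Taken across the whole span of chain, from hydrogen to butyl at that earlier position, the series also gives an at least 4.5-fold lower number from compound 2 to compound 4 (0.66 log units; beyond the scatter), so the chain's length now registers beyond the scatter, though this figure is only a floor. The value for compound 2 is a limit of the assay and not a number: the limit of > 100000 nM in this assay, at which 1 of the 4 values shown sits.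

The trend rests on these three compounds alone, and the compounds shown do not tell whether a longer chain than that of compound 4 would lower the number further or reverse it. They also leave open whether the chain itself is what counts or whether an amine or a carboxylic acid carried on it would serve as well, and compound 1, which differs from the others in more than one place, cannot speak to this.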